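Thiosemicarbazones on a shared terpene core: swapping the aryl group

The source may hold more compounds than are shown below. What is called first, only, known or untested is meant among the compounds shown, and "the series" means these compounds.

Compound 1 `CC1=CC[C@@H]([C@@](C)(O)CCCC(C)(C)NC(=S)N/N=C\c2ccc(C)cc2)CC1`: 6750 nM
Compound 2 `CC1=CC[C@@H]([C@@](C)(O)CCCC(C)(C)NC(=S)N/N=C\c2cccc(Cl)c2)CC1`: 11300 nM

In a functional assay on PCO3 cells (Homo sapiens) for cytotoxicity, read by sulforhodamine B assay (on this read-out lower numbers stand for stronger inhibition of growth and higher numbers for weaker inhibition of growth), compound 2 carries the upper of the two numbers, with compound 1 nearest, and the step of a 1.7-fold higher number from compound 1 to compound 2 (0.22 log units; within the scatter) lies within the scatter. Compound 3 `CC1=CC[C@@H]([C@@](C)(O)CCCC(C)(C)NC(=S)N/N=C(/C)c2ccccc2)CC1` differs from compound 2 by a group of 9 heavy atoms (8 carbon, 1 nitrogen; one six-membered aromatic ring of carbon only) in place of a group of 9 heavy atoms (7 carbon, 1 nitrogen, 1 chlorine; one six-membered aromatic ring of carbon only), on an amide-type nitrogen. Among the compounds with values here, the only measured step that bears on such a change, a 1.7-fold higher number from compound 1 to compound 2 (0.22 log units; within the scatter), also exchanged one aromatic group for another and produced nothing beyond the scatter. For compound 3 no step beyond the scatter is therefore expected, a 1.3-fold lower number from compound 2 to compound 3 (0.10 log units; within the scatter). Compound 3 is estimated at 9000 nM, with a range from 3000 nM to 27000 nM.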

Compound 3, concentration for 50% growth inhibition: 20000 nM
Estimate against measurement, compound 3: 2.2-fold (0.35 log units) below; low and high end bracket the measured number.
By their numbers in this assay, from the lowest: compounds 1, 2 and 3 (each within the scatter of the next, the first and the last beyond it).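

In this assay, within the data shown here, the step of a 3.0-fold higher number from compound 1 to compound 3 (0.47 log units; beyond the scatter) is modest but passes beyond the scatter, the first change at this place on the amide-type nitrogen to do so. The step of a 1.8-fold higher number from compound 2 to compound 3 (0.25 log units; within the scatter) stays within the scatter, so compound 3 stands clearly apart from compound 1 only. Nothing available explains this difference.

As far as these compounds go, the whole group changes in each step, so which part of it matters stays open. From the compounds shown here alone, how a group carrying an amine or a carboxylic acid would read at this place is also open.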